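A few compounds are considered here, and "the series" means these few. Any claim that something is new, unique, unknown or untested is made for them only; others in the source may bear on it.

Compound 1 `Nc1nccc(-c2sc(C3CNCCN3)nc2-c2cccc(NS(=O)(=O)c3cc(F)ccc3F)c2F)n1`: 127 nM
Compound 2 `Nc1nccc(-c2sc(C3COCCN3)nc2-c2cc(Cl)cc(NS(=O)(=O)c3cc(F)ccc3F)c2F)n1`: 2.06 nM

Both compounds were tested in a functional assay on A-375 cells (Homo sapiens) for inhibition, read by MTT assay, with a stated time of 5 days; a lower number here means a stronger inhibitor, a higher number a weaker inhibitor. There, compound 1 gives 127 nM and stands as the weaker inhibitor of the two, its number higher than that of compound 2 by more than the scatter of repeated measurements. Compound 3 `NCCCc1nc(-c2cccc(NS(=O)(=O)c3cc(F)ccc3F)c2F)c(-c2ccnc(N)n2)s1` still awaits its measurement in this assay. It departs from compound 1 in one place, on an aromatic carbon of a five-membered aromatic ring with 1 nitrogen and 1 sulfur: 3-aminopropyl stands in place of piperazin-2-yl (3-aminopropyl in place of piperazin-2-yl on an aromatic carbon). For the measured compounds named here, no measured pair isolates this change: compound 2 differs from compound 1 in more than this one place. The expected step, a 1.3-fold lower number from compound 1 to compound 3 (0.10 log units; within the scatter), is therefore small, in no firm direction and probably not beyond the scatter. The estimated value for compound 3 is 100 nM, with an expected range of 20 nM to 500 nM.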

Compound 3, half-maximal inhibitory concentration: 39.5 nM
Estimate against measurement, compound 3: 2.5-fold (0.40 log units) above, within the range that was stated.
By their numbers in this assay, from the lowest: compound 2; then compound 3; then compound 1.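

In this assay, replacing piperazin-2-yl with 3-aminopropyl on this aromatic carbon, next to the ring nitrogen and next to the ring sulfur, gives a 3.2-fold lower number from compound 1 to compound 3 (0.51 log units; beyond the scatter), a modest gain. For the compounds shown here, this is the first pair to isolate this place, and it shows that, on the core of compound 1, the six-membered ring is not needed for activity: the open chain, with fewer heavy atoms and one hydrogen-bond donor and acceptor in place of two of each, gives the lower number. The data shown offer no measurement that accounts for this step.

On these data alone, it remains open whether the length of the chain matters, as a 2-aminoethyl or 4-aminobutyl group would show, and whether the terminal amine matters, as a hydroxyl in its place would show. Also open, as far as these compounds go, is whether the same change would give a similar step on the core of compound 2.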